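This account rests on a few compounds, and the source may have more. Where it says the series, first, only, none or still open, it means among the compounds named here.

Measured so far:
- compound 1 `O=C(CCc1ccc(C(F)(F)F)cc1)Nc1ccc2nc(N3CC4CC3CN4)ccc2c1` — 490 nM
- compound 2 `O=C(CCCCCCCCCCCCc1ccc(C(F)(F)F)cc1)Nc1ccc2nc([N+]34CCC(CC3)CC4)ccc2c1` — 25 nM

In a functional assay on HEK293 cells for activation of melanin-concentrating hormone receptor 1 (Rattus norvegicus), read by inositol phosphate accumulation (on this read-out lower numbers stand for an effect already at smaller amounts and higher numbers for an effect only at larger amounts of compound), compound 1 gives 490 nM and stands highest of the two numbers; the nearest is compound 2, whose value in this assay is 25 nM, a lower number by a gap beyond the scatter. The two differ in many places at once, so nothing can be read from that gap for a single change.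

Compound 3 `O=C(CCc1ccc(C(F)(F)F)cc1)Nc1ccc2nc(N3CC4CC3CO4)ccc2c1` is not yet measured. Relative to compound 1 it carries a group of 7 heavy atoms (5 carbon, 1 nitrogen, 1 oxygen; 2 five-membered non-aromatic rings with 1 hetero atom each) in place of a group of 7 heavy atoms (5 carbon, 2 nitrogen; 2 five-membered non-aromatic rings with 1 hetero atom each), on an aromatic carbon The change is confined to the bicyclic substituent on the shared core; the amide chain and the trifluoromethyl-bearing ring are unchanged.

Among the compounds with values here, no step in this assay is available for this exchange, and the only other compound, compound 2, gives no guidance on it. The expectation is a modest step in this assay toward higher numbers, within or just beyond the scatter; a step in the other direction cannot be excluded on these data.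

For compound 3 the expected value in this assay is 900 nM, with a range of 250 nM to 3500 nM; the step from compound 1 to compound 3 is thus estimated as a 1.8-fold higher number from compound 1 to compound 3 (0.26 log units; within the scatter).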

Compound 3, half-maximal effective concentration: 70 nM
Compound 3: middle estimate off by 13-fold (1.11 log units), on the high side, and the stated range ends above it.
By their numbers in this assay, from the lowest: compound 2; then compound 3; then compound 1.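

In this assay, within the data shown here, the exchange of the nitrogen-bearing bicyclic group for the oxygen-bearing one gives a 7.0-fold lower number from compound 1 to compound 3 (0.85 log units; beyond the scatter) and is the first single-place step. The amide chain and the trifluoromethyl-bearing ring stay the same, so this position, on an aromatic carbon next to the ring nitrogen, clearly affects the read-out even though the group keeps its 7 heavy atoms and both five-membered non-aromatic rings. The count falls from 1 hydrogen-bond donor to 0 hydrogen-bond donors while 2 hydrogen-bond acceptors remain, so a donor in this group is not required for the lower number seen here, and no measurement in hand bears on why the number falls.

On these data alone, it remains open whether the step follows the loss of the donor or the oxygen itself, a question that a methyl group on the nitrogen or a sulfur atom in place of the oxygen would help to separate. As far as these compounds go, it is also open whether the same exchange gives a step of similar size when a longer chain sits on the amide.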